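Iodo for Propyl on the Anilino Ring of a Tricyclic Core

The source may hold more compounds than are shown below. What is called first, only, known or untested is meant among the compounds shown, and "the series" means these compounds.

Measured compounds:
compound 1 `CCCc1ccc(NC2=CC(=O)c3nc4n(c3C2=O)[C@H]2OC[C@@H](O)[C@H]2OC4)cc1`, 4660 nM
compound 2 `Cc1ccc(NC2=CC(=O)c3c(nc4n3[C@H]3OC[C@@H](O)[C@H]3OC4)C2=O)cc1C`, 4950 nM
compound 3 `O=C1C(N2CCCC2)=CC(=O)c2c1nc1n2[C@H]2OC[C@@H](O)[C@H]2OC1`, only a limit, > 16000 nM

In a functional assay on MCF7 cells (Homo sapiens) for inhibition, read by sulforhodamine B assay (on this read-out lower numbers stand for stronger inhibition and higher numbers for weaker inhibition), compound 1 gives 4660 nM, the lowest of the two numbers shown, and compound 2 gives 4950 nM, a gap within the scatter. Compound 3 reaches only the limit of this assay, (the limit of > 16000 nM in this assay, at which 1 of the 3 values shown sits). For the measured compounds named here, the one measured step, an at least 3.2-fold higher number from compound 2 to compound 3 (0.50 log units; beyond the scatter), swaps the whole arylamino group for a cyclic amine and so bears only loosely on the change considered here.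

Compound 4 `O=C1C=C(Nc2ccc(I)cc2)C(=O)c2c1nc1n2[C@H]2OC[C@@H](O)[C@H]2OC1` differs from compound 1 by iodo in place of propyl on an aromatic carbon. Both arylamino analogues, compound 1 and compound 2, sit within the scatter of each other in this assay, so a substituent change on that ring is not expected to move the number beyond the scatter. Compound 4 is therefore estimated at 5000 nM, with a range from 2000 nM to 13000 nM. The expected step from compound 1 is a 1.1-fold higher number from compound 1 to compound 4 (0.03 log units; within the scatter), essentially none beyond the scatter.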

Compound 4, half-maximal inhibitory concentration: 2230 nM
Estimate against measurement, compound 4: 2.2-fold (0.35 log units) above; the range from low to high includes it.
By their numbers in this assay, from the lowest: compound 4; then compounds 1 and 2 (each within the scatter of the next). At a limit, above all of these: compound 3.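

In this assay the change from propyl to iodo gives a 2.1-fold lower number from compound 1 to compound 4 (0.32 log units; beyond the scatter), a modest step and the first measured one that alters a single substituent while keeping the arylamino link and its aromatic ring. The earlier step replaced the whole arylamino group, and compound 1 and compound 2 differ in more than one place, so neither could isolate this position. The step shows that the number responds to the group at this position, para to a large group, and that the propyl chain is not needed to reach the number of compound 1.

On these data alone, whether bromo, chloro, methoxy, an amine, a carboxylic acid or a longer chain on this carbon would lower or raise the number remains open. Nothing measured in this set gives a reason for the step.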